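This account rests on a few compounds, and the source may have more. Where it says the series, first, only, none or still open, it means among the compounds named here.

Notes on the series. Compound 1 `Cc1ccc(-c2nc3ccc(F)cc3s2)cc1N` and compound 2 `CC1(C)O[C@H]2O[C@H]([C@H]3COC(C)(C)O3)[C@H](OCc3ccc(-c4nc5ccc(F)cc5s4)cc3)[C@H]2O1` are the measured members. In a functional assay on Jurkat cells (Homo sapiens) for cytotoxicity, read by MTT assay, with a stated time of 2 days (a higher number here means a weaker inhibitor, a lower number a stronger inhibitor), compound 1 returns only a limit, > 50000 nM. In this assay compound 2 likewise returns only a limit, > 50000 nM. Among the measured compounds shown here, compound 2 therefore stands where every value so far stands, at the limit of > 50000 nM in this assay, at which 2 of the 2 values shown sit; no step between measured compounds can be read. Compound 3 `CC1(C)O[C@H]2O[C@H]([C@H](O)CO)[C@H](OCc3ccc(-c4nc5ccc(F)cc5s4)cc3)[C@H]2O1` is not yet measured. It differs from compound 2 by 1,2-dihydroxyethyl in place of 2,2-dimethyl-1,3-dioxolan-4-yl on a saturated ring carbon. With both measured values sitting at the limit, no direction for the change is indicated, and the step is estimated as a step that the limit leaves unreadable from compound 2 to compound 3, nothing beyond the scatter. Compound 3 is expected to give 70000 nM in this assay, within 25000 nM to 200000 nM, and most likely to be reported again only as a limit.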

Compound 3, half-maximal inhibitory concentration: 3200 nM
Compound 3: the middle estimate sits 22-fold (1.34 log units) above what was measured, outside the stated range (below it).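

In this assay, 1,2-dihydroxyethyl in place of 2,2-dimethyl-1,3-dioxolan-4-yl, on the saturated ring carbon next to the ring oxygen, gives an at least 15-fold lower number from compound 2 to compound 3 (1.19 log units; beyond the scatter). This position is therefore not silent in the series, and of the compounds shown, compound 3 alone returns a number rather than a limit. The size of the step is only a bound, because compound 2 rests at a limit: the limit of > 50000 nM in this assay, at which 2 of the 3 values shown sit.

The compounds shown leave open whether the change depends on the open chain itself, on both of its hydroxyl groups or on the defined stereocentre it carries. From the compounds shown here alone, a hydroxymethyl, an aminoethyl or a carboxylic acid on the same ring carbon would help separate these readings, and the effect of such groups on the core remains unknown here.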